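This account rests on a few compounds, and the source may have more. Where it says the series, first, only, none or still open, it means among the compounds named here.

Measured compounds in an ADME assay on A549 cells (Homo sapiens) for cytotoxicity, read by CellTiter-Glo; on this read-out higher numbers stand for lower toxicity in this test and lower numbers for higher toxicity in this test:

Compound 1 `Cc1c(Cc2ccc(C(C)(C)C)cc2)c(=O)oc2cc(OCC(O)CN3CCC(C(N)=O)CC3)ccc12`, in this assay compound 1 gives 14700 nM.
Compound 2 `Cc1c(Cc2ccc(F)cc2Cl)c(=O)oc2cc(OCC(O)CN3CCC(C(N)=O)CC3)ccc12`, in this assay compound 2 gives 90800 nM.

Within the data shown here, compound 2 holds the highest of the two numbers so far; its only neighbour is compound 1, reached by a 6.2-fold higher number from compound 1 to compound 2 (0.79 log units; beyond the scatter). Among the measured compounds shown here, that step swapped the aryl group on the saturated chain carbon bound to an aromatic carbon, and it is the one measured step that bears on the next change.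

Compound 3 `COc1ccc(Cc2c(C)c3ccc(OCC(O)CN4CCC(C(N)=O)CC4)cc3oc2=O)c(Br)c1` differs from compound 2 at the same place: 2-bromo-4-methoxyphenyl in place of 2-chloro-4-fluorophenyl on a saturated chain carbon bound to an aromatic carbon. For the measured compounds named here, the ring keeps a halogen at the 2-position and changes the 4-substituent, so the change is smaller in kind than the one from compound 1 to compound 2, and there is no measured step that isolates either part of it. Going by the values given here, the single step seen at this position was modest, and the new group lies structurally between the two measured aryl groups.

Compound 3 is therefore expected to sit near compound 2, with the step of a 1.5-fold lower number from compound 2 to compound 3 (0.18 log units; within the scatter) expected to be small and, if anything, downward. The estimate for compound 3 in this assay is 60000 nM, with a range from 20000 nM to 150000 nM.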

Compound 3, half-maximal cytotoxic concentration: 44400 nM
Compound 3: middle estimate off by 1.4-fold (0.13 log units), on the high side; low and high end bracket the measured number.
By their numbers in this assay, from the lowest: compound 1; then compound 3; then compound 2.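

In this assay, the step of a 2.0-fold lower number from compound 2 to compound 3 (0.31 log units; beyond the scatter) shows that the number still responds when 2-bromo-4-methoxyphenyl replaces 2-chloro-4-fluorophenyl on a saturated chain carbon bound to an aromatic carbon, even though the step is modest and only just beyond the scatter. The step of a 3.0-fold higher number from compound 1 to compound 3 (0.48 log units; beyond the scatter) is smaller than the step of a 6.2-fold higher number from compound 1 to compound 2 (0.79 log units; beyond the scatter) but runs in the same direction, so among the three compounds both halogen-bearing aryl groups give higher numbers than 4-(tert-butyl)phenyl, with none going against this order. No independent measurement on these compounds accounts for that order.

The bromine and the methoxy group enter together, so the compounds shown cannot divide the step between them, and a compound changing only one of the two would be needed to do so. From the compounds shown here alone, how an amine or a carboxylic acid on this aryl group would read in this assay remains open, as does any change elsewhere on the shared core.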